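This account rests on a few compounds, and the source may have more. Where it says the series, first, only, none or still open, it means among the compounds named here.

Measured so far:
compound 1 `CN(C)CCn1cnnc1-c1cc(Oc2ccc(NC(=O)N/N=C/c3c(Cl)cccc3Cl)cc2F)ccn1`, which in a functional assay on U-87MG ATCC cells (Homo sapiens) for cytotoxicity, read by MTT assay, with a stated time of 72 h (a higher number here means a weaker inhibitor, a lower number a stronger inhibitor), gives > 100000 nM, a limit of the assay and not a number;
compound 2 `COc1ccc(/C=N/NC(=O)Nc2ccc(Oc3ccnc(-c4nncn4CCN(C)C)c3)c(F)c2)c(OC)c1OC`, which in this assay gives 7650 nM;
compound 3 `CN(C)CCn1cnnc1-c1cc(Oc2ccc(NC(=O)N/N=C/c3ccccc3O[N+](=O)[O-])cc2F)ccn1`, which in this assay gives 7150 nM.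

Compound 3 holds the lowest of the two numbers, with compound 2 nearest; the step of a 1.1-fold lower number from compound 2 to compound 3 (0.03 log units; within the scatter), so the two are not told apart. Compound 1 sits at the limit of > 100000 nM in this assay, at which 1 of the 3 values shown sits. Compound 4 `CN(C)CCn1cnnc1-c1cc(Oc2ccc(NC(=O)N/N=C/c3ccc(F)cc3)cc2F)ccn1` has not yet been measured; the change is 4-fluorophenyl in place of 2-(nitrooxy)phenyl on a carbon with a double bond to nitrogen. Two measured steps vary the same aryl group on that carbon: an at least 13-fold lower number from compound 1 to compound 3 (1.14 log units; beyond the scatter) and a 1.1-fold lower number from compound 2 to compound 3 (0.03 log units; within the scatter). Exchanging this aryl can thus move the number a great deal or not at all, and nothing shown places a 4-fluorophenyl on either side. Compound 4 is expected to stay near compound 3, a 1.4-fold higher number from compound 3 to compound 4 (0.15 log units; within the scatter), with an estimate of 10000 nM ranging from 3000 nM to 50000 nM.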

Compound 4, half-maximal inhibitory concentration: 2310 nM
The estimate for compound 4 lay 4.3-fold (0.64 log units) above the measured number, and the stated range ends above it.
By their numbers in this assay, from the lowest: compound 4; then compounds 3 and 2 (each within the scatter of the next). At a limit, above all of these: compound 1.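

In this assay, the aryl group on a carbon with a double bond to nitrogen now separates compounds where compound 2 and compound 3 could not be told apart: a 3.1-fold lower number from compound 3 to compound 4 (0.49 log units; beyond the scatter), and a 3.3-fold lower number from compound 2 to compound 4 (0.52 log units; beyond the scatter). The widest step in the series is an at least 43-fold lower number from compound 1 to compound 4 (1.63 log units; beyond the scatter). Compound 1 stands at a limit and not a number: the limit of > 100000 nM in this assay, at which 1 of the 4 values shown sits.

Halogen alone sets no rule, since the 2,6-dichlorophenyl of compound 1 goes against the 4-fluorophenyl of compound 4. On these data alone, whether a single chlorine, an amine or a carboxylic acid at the place of that fluorine would hold the number remains open.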